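The compounds below may be only part of what the source reports. "The series", "measured", "known", "first", "only" and "open" are said of these compounds alone.

- compound 1 `CCn1cc(-c2nc3ccccc3o2)c(=O)c2cc(F)c(N3CCNC(C)C3)c(F)c21` gives 5700 nM
- compound 2 `CCn1cc(-c2nc3ccccc3o2)c(=O)c2cc(F)c(N3CCNCC3)nc21` gives 16800 nM
- compound 3 `CCn1cc(-c2nc3ccccc3s2)c(=O)c2cc(F)c(N3CCNC(C)C3)c(F)c21` gives 15000 nM

In a functional assay on Bel-7402 cells (Homo sapiens) for cytotoxicity, read by MTT assay, with a stated time of 48 h (on this read-out higher numbers stand for weaker inhibition and lower numbers for stronger inhibition), compound 2 sits at 16800 nM, level with compound 3 at 15000 nM within the usual scatter, while compound 1 shows the clearly lower number, 5700 nM. Compound 4 `CCn1cc(-c2nc3ccc(Cl)cc3[nH]2)c(=O)c2cc(F)c(N3CCNCC3)nc21` keeps the core of compound 2 and exchanges one group, 6-chloro-1H-benzimidazol-2-yl in place of 1,3-benzoxazol-2-yl on an aromatic carbon. For the measured compounds named here, only one measured step bears on this. Replacing 1,3-benzoxazol-2-yl with 1,3-benzothiazol-2-yl gave a 2.6-fold higher number from compound 1 to compound 3 (0.42 log units; beyond the scatter), a modest change. Going by the values given here, that step sits on the core of compound 1, and no measured compound carries the new group, so the data suggest a size but not a firm direction. The expected change in this assay is therefore modest, an estimated 1.4-fold lower number from compound 2 to compound 4 (0.15 log units; within the scatter), and either direction remains possible. For compound 4 the expected value is 12000 nM, with an estimated range from 4000 nM to 35000 nM.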

Compound 4, half-maximal inhibitory concentration: 21500 nM
For compound 4 the middle estimate is 1.8-fold (0.25 log units) below the measured one; low and high end bracket the measured number.
By their numbers in this assay, from the lowest: compound 1; then compounds 3, 2 and 4 (each within the scatter of the next).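

In this assay, 6-chloro-1H-benzimidazol-2-yl in place of 1,3-benzoxazol-2-yl on the core of compound 2 gives a 1.3-fold higher number from compound 2 to compound 4 (0.11 log units; within the scatter), so the two groups cannot be told apart at this position. The entering group brings a chlorine and a hydrogen-bond donor, yet the read-out stays level, whereas the earlier exchange of 1,3-benzoxazol-2-yl for 1,3-benzothiazol-2-yl, on the core of compound 1, went beyond the scatter. No measurement at hand explains this difference.

The compounds shown leave open what the chlorine contributes on its own, a question that a plain benzimidazol-2-yl group or one carrying a methoxy or an amine instead of the chlorine could address. As far as these compounds go, it also remains open whether 1,3-benzothiazol-2-yl would give the same step on the core of compound 2 as on the core of compound 1.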